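The source may report more compounds than this note shows. Statements on the series, on what has been measured and on what is new or still open speak of the compounds shown alone.

Measured compounds:
compound 1 `O=c1cc(CCl)c2ccc(OCc3cccc(Cl)c3)cc2o1`, in an assay on isolated protein (strain Sprague-Dawley) for inhibition of Amine oxidase [flavin-containing] B (Rattus norvegicus), read by spectrophotometry, with a stated time of 5 min (a lower number here means a stronger inhibitor, a higher number a weaker inhibitor), compound 1 gives 43.7 nM
compound 2 `O=c1cc(CO)c2ccc(OCc3cccc(Cl)c3)cc2o1`, compound 2 gives 5.25 nM
compound 3 `O=c1cc(CCl)c2ccc(OCc3cccc(Br)c3)cc2o1`, compound 3 gives 209 nM

Compound 4 `O=c1cc(CO)c2ccc(OCc3cccc(Br)c3)cc2o1` is not yet measured. The change from compound 3 to compound 4 is hydroxy in place of chloro on a saturated chain carbon bound to an aromatic carbon; the same change, on the same place, has been made once already, as hydroxy in place of chloro on a saturated chain carbon bound to an aromatic carbon, and there it gave an 8.3-fold lower number from compound 1 to compound 2 (0.92 log units; beyond the scatter). The cores of the two pairs differ by bromo in place of chloro on an aromatic carbon, a change that gave a 4.8-fold higher number from compound 1 to compound 3 (0.68 log units; beyond the scatter).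

Going by the values given here, for compound 4 a step of similar size is expected, a 7.5-fold lower number from compound 3 to compound 4 (0.87 log units; beyond the scatter), resting on the single measured pair, because the step of an 8.3-fold lower number from compound 1 to compound 2 (0.92 log units; beyond the scatter) is the only precedent. Compound 4 is therefore estimated at 28 nM, with the range 9 nM to 90 nM.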

Compound 4, half-maximal inhibitory concentration: 14.1 nM
Estimate against measurement, compound 4: 2.0-fold (0.30 log units) above; measured number inside the range.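

In this assay the change from chloromethyl to hydroxymethyl lowers the number on both cores, and a 15-fold lower number from compound 3 to compound 4 (1.17 log units; beyond the scatter) agrees with the earlier step: the same change on two cores in this assay, an 8.3-fold lower number (0.92 log units; beyond the scatter) from compound 1 to compound 2 and a 15-fold lower number (1.17 log units; beyond the scatter) from compound 3 to compound 4, 1.8-fold (0.25 log units) apart, within the scatter of two such steps

Bromo in place of chloro on an aromatic carbon raises the number with either group on the chain, with a 2.7-fold higher number from compound 2 to compound 4 (0.43 log units; beyond the scatter) on the hydroxymethyl core: the same change on two cores in this assay, a 4.8-fold higher number (0.68 log units; beyond the scatter) from compound 1 to compound 3 and a 2.7-fold higher number (0.43 log units; beyond the scatter) from compound 2 to compound 4, 1.8-fold (0.25 log units) apart, within the scatter of two such steps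

These four compounds show that the two changes carry over between these two cores, but two pairs per change do not establish a rule for other cores.

Still open, from the compounds shown here alone, is whether an amine, a carboxylic acid or a longer chain bearing the hydroxy would fare as hydroxymethyl does. Also open, going by these compounds, is how fluoro on that aromatic carbon would compare with chloro and bromo.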